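Shortening the linker in the piperidine series

The source may report more compounds than this note shows. Statements on the series, on what has been measured and on what is new or still open speak of the compounds shown alone.

Compound 1 `C[C@@H](NCC1CCN(CCCc2c[nH]c3ccc(-n4cnnc4)cc23)CC1)c1ccccc1` sits at the strong end of the three numbers in hand: in an assay on CHO cells for displacement of a labelled ligand from 5-hydroxytryptamine receptor 1D (Homo sapiens) (a higher number here means a weaker inhibitor, a lower number a stronger inhibitor), compound 1 gives 1.4 nM. Compound 2 `c1ccc(CNCC2CCN(CCCc3c[nH]c4ccc(-n5cnnc5)cc34)CC2)cc1` gives 1.6 nM, and the step of a 1.1-fold higher number from compound 1 to compound 2 (0.06 log units; within the scatter) shows that hydrogen in place of methyl on the chain carbon changes nothing of note. Compound 3 `c1cc(CNC2CCN(CCCc3c[nH]c4ccc(-n5cnnc5)cc34)CC2)co1` gives 4.5 nM; here the amine sits directly on the saturated ring carbon, with ((furan-3-yl)methyl)amino in place of ((1-phenylethyl)amino)methyl, and the step is a 3.2-fold higher number from compound 1 to compound 3 (0.51 log units; beyond the scatter), with a 2.8-fold higher number from compound 2 to compound 3 (0.45 log units; beyond the scatter) for the matching change from compound 2.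

Compound 4 `C[C@@H](NC1CCN(CCCc2c[nH]c3ccc(-n4cnnc4)cc23)CC1)c1ccccc1` keeps the phenylethyl group and the shared core but shortens the link: (1-phenylethyl)amino in place of ((1-phenylethyl)amino)methyl on a saturated ring carbon. Within the data shown here, the only measured steps that remove that methylene also swap the aryl group, so the two changes cannot be separated; both gave a modest weakening. A comparable or somewhat smaller weakening is expected here, so compound 4 is estimated at 3 nM, range 1.2 nM to 8 nM, meaning an expected step of a 2.1-fold higher number from compound 1 to compound 4 (0.33 log units; beyond the scatter).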

Compound 4, half-maximal inhibitory concentration: 0.4 nM
Beside the measured number, compound 4's estimate is 7.5-fold (0.88 log units) above it; measured number outside the range, below it.
By their numbers in this assay, from the lowest: compound 4; then compounds 1 and 2 (each within the scatter of the next); then compound 3.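

With the 1-phenylethyl group kept, removing the methylene alone strengthens binding in this assay, giving a 3.5-fold lower number from compound 1 to compound 4 (0.54 log units; beyond the scatter), so the shorter link is not itself a source of weakening at this saturated ring carbon. The change of group on the amine nitrogen matters on the shortened link, where 1-phenylethyl in place of (furan-3-yl)methyl gives an 11-fold lower number from compound 3 to compound 4 (1.05 log units; beyond the scatter), the largest step in the set. The combined change from (benzylamino)methyl to (1-phenylethyl)amino gives a 4.0-fold lower number from compound 2 to compound 4 (0.60 log units; beyond the scatter), and nothing available bears on why the shorter link behaves this way.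

Open, on these data alone, is whether plain benzylamino on the same ring carbon would match the 1-phenylethyl result, which would show how much depends on the added methyl on the shortened link. Also open, as far as these compounds go, is how a two-carbon chain between the ring carbon and the amine nitrogen would compare.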